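Swapping Ethylsulfanyl for Methylamino on a Shared Core

This account rests on a few compounds, and the source may have more. Where it says the series, first, only, none or still open, it means among the compounds named here.

Two measured compounds share one core and differ at a single aromatic carbon. Compound 1 `CCCc1nc2cccc(C(=O)O)c2n1Cc1ccc(-c2ccccc2-c2noc(O)n2)cc1` carries a propyl group there; in a functional assay on the whole organism for inhibition, with Rattus norvegicus as the target, with a stated time of 7 h, at a dose of 1 mg/kg by the oral route (on this read-out lower numbers stand for less inhibition and higher numbers for more inhibition at the one dose given (going by the name of the read-out)), compound 1 gives 88%. Compound 2 `CCSc1nc2cccc(C(=O)O)c2n1Cc1ccc(-c2ccccc2-c2noc(O)n2)cc1` carries an ethylsulfanyl group instead, and in this assay compound 2 gives 100%. That single swap produced a number 12 percentage points higher from compound 1 to compound 2 (beyond the scatter). Of the two measured numbers, compound 2 stands highest, with compound 1 nearest and lower by that same step.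

Compound 3 `CNc1nc2cccc(C(=O)O)c2n1Cc1ccc(-c2ccccc2-c2noc(O)n2)cc1` takes the next step from compound 2: methylamino in place of ethylsulfanyl on an aromatic carbon. Among the measured compounds shown here, no measured step covers an exchange of this kind; the only measured step, from propyl to ethylsulfanyl, was modest in size and moved the read-out upward. Compound 2 already stands at the ceiling of the scale, where a further rise cannot be read, and a small fall or no change beyond the scatter is the likelier outcome. Compound 3 is expected to give about 85% in this assay, within 60% to 100%. The expected step is therefore a number 15 percentage points lower from compound 2 to compound 3 (beyond the scatter).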

Compound 3, a percentage reported as inhibition, in the whole organism at one dose (the size of the read-out at that dose, not a potency): 13%
Compound 3: middle estimate off by 72 percentage points, on the high side; the measured number lies below the stated range.
By their numbers in this assay, from the lowest: compound 3; then compound 1; then compound 2.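

In this assay, among the compounds shown here, this position proves far more sensitive than the one earlier step suggested: methylamino in place of ethylsulfanyl gives a number 87 percentage points lower from compound 2 to compound 3 (beyond the scatter), and methylamino in place of propyl gives a number 75 percentage points lower from compound 1 to compound 3 (beyond the scatter). Both steps are large, whereas the step from propyl to ethylsulfanyl was modest, so the group on this aromatic carbon between two ring nitrogen atoms can decide much of the read-out at this single oral dose. The exchange from ethylsulfanyl to methylamino replaces sulfur with nitrogen, removes one carbon and adds a hydrogen-bond donor, but no measurement here explains why the read-out falls so far.

The compounds shown cannot separate the effect of the nitrogen itself from that of the hydrogen it carries, a question that a dimethylamino group at this position would help to answer. An ethylamino group would keep the nitrogen and hydrogen while lengthening the chain, and a methoxy group would place oxygen at the same point, so each could show which part of the change matters.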